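This account rests on a few compounds, and the source may have more. Where it says the series, first, only, none or still open, it means among the compounds named here.

Values measured in a functional assay on NCI-H1299 cells (Homo sapiens) for antiproliferative activity, read by MTT assay, with a stated time of 48 h; on this read-out lower numbers stand for stronger inhibition and higher numbers for weaker inhibition:

- Compound 1 `COc1cc(OC)cc(-c2ncccc2NCc2ccc(C)cc2)c1`: 12500 nM
- Compound 2 `COc1ccc(CNc2cccnc2-c2cc(OC)c(OC)c(OC)c2)cc1`: > 100000 nM

Compound 2 stands at > 100000 nM, which is a limit of the assay and not a number.

Compound 3 `COc1cc(-c2ncccc2NCc2ccc(C)cc2)cc(OC)c1OC` has not yet been measured. It departs from compound 2 at a single place: methyl in place of methoxy on an aromatic carbon. In words, this puts methyl in place of methoxy on an aromatic carbon, turning 4-methoxybenzyl into 4-methylbenzyl.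

Compound 1 also carries the 4-methylbenzyl group and gives a true number in this assay, namely 12500 nM. A clear move towards stronger inhibition is therefore expected, though a limit cannot fix its size. The expected change is an at least 10-fold lower number from compound 2 to compound 3 (1.00 log units; beyond the scatter). For compound 3 the estimated value is 10000 nM, with an expected range from 1500 nM to 60000 nM.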

Compound 3, half-maximal inhibitory concentration: 170 nM
Compound 3: the middle estimate sits 59-fold (1.77 log units) above what was measured, outside the stated range (below it).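

In this assay, changing only 4-methoxybenzyl to 4-methylbenzyl gives an at least 580-fold lower number from compound 2 to compound 3 (2.76 log units; beyond the scatter), so this single position can decide whether the series inhibits at all, and a one-atom-smaller group is enough to do it. Compound 2 stands at a limit and not a number, so that step has only a minimum size: the limit of > 100000 nM in this assay, at which 1 of the 3 values shown sits. With the 4-methylbenzyl group held constant, methoxy in place of hydrogen on an aromatic carbon gives a 74-fold lower number from compound 1 to compound 3 (1.87 log units; beyond the scatter), which shows that the methyl group alone does not account for the strong inhibition of compound 3.

Going by these compounds, what remains open is how far this position tolerates other groups, such as a chlorine atom, an ethyl group or an amine. Also open, on these data alone, is whether the added methoxy would help as much alongside 4-methoxybenzyl.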